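Cyano to fluoro: does a small change make a small step?

A few compounds are considered here, and "the series" means these few. Any claim that something is new, unique, unknown or untested is made for them only; others in the source may bear on it.

Three compounds have been measured in a functional assay on QG-56 cells (Homo sapiens) for antiproliferative activity; on this read-out higher numbers stand for weaker inhibition and lower numbers for stronger inhibition:
Compound 1, `Cn1cncc1C(O)(c1ccc(C#N)cc1)c1cc2cc([N+](=O)[O-])cc(-c3ccc(C#N)cc3)c2o1`: 32.6 nM
Compound 2, `Cn1cncc1[C@@](N)(c1ccc(C#N)cc1)c1cc2cc(C#N)cc(-c3cccc(C#N)c3)c2o1`: 2 nM
Compound 3, `Cn1cncc1[C@@](N)(c1ccc(C#N)cc1)c1cc2cc(C#N)cc(-c3cccc(F)c3)c2o1`: 2 nM

Compound 1 gives the highest number of the three, and its gaps to compound 2 and to compound 3 both lie beyond the scatter. How the core of compound 1 differs from that of compound 2 is not broken down here. The change between compound 2 and compound 3 is fluoro in place of cyano on an aromatic carbon. Measured, no change at the digits printed from compound 2 to compound 3 (within the scatter).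

Compound 4, `Cn1cncc1C(O)(c1ccc(C#N)cc1)c1cc2cc([N+](=O)[O-])cc(-c3ccc(F)cc3)c2o1`, is not yet measured; it differs from compound 1 by fluoro in place of cyano on an aromatic carbon. This is the same kind of change as that between compound 2 and compound 3, not the same: there the place is meta to a large group, here para to a large group. Because no change at the digits printed from compound 2 to compound 3 (within the scatter) showed no movement, the step of a 1.0-fold higher number from compound 1 to compound 4 (0.01 log units; within the scatter) is expected to be small too. Compound 4 is estimated at 33 nM, between 12 nM and 90 nM.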

Compound 4, half-maximal inhibitory concentration: 158 nM
For compound 4 the middle estimate is 4.8-fold (0.68 log units) below the measured one; measured number outside the range, above it.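

Fluoro in place of cyano does not give the same result on every core in this assay, as this time the swap gives a 4.8-fold higher number from compound 1 to compound 4 (0.69 log units; beyond the scatter). Set side by side, the two steps differ, so the result from one core cannot simply be carried to the other: the same change on two cores in this assay, no change at the digits printed (within the scatter) from compound 2 to compound 3 and a 4.8-fold higher number (0.69 log units; beyond the scatter) from compound 1 to compound 4, 4.8-fold (0.69 log units) apart, beyond the scatter of two such steps. This does not show whether the core or the place of the swap on the ring accounts for the gap, and a single pair on each core gives no general rule.

The compounds shown leave open how the swap would behave on a third core. They also leave open whether chloro, methoxy or an amine in the same place would track fluoro on both cores.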